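The source may report more compounds than this note shows. Statements on the series, on what has been measured and on what is new or still open speak of the compounds shown alone.

In a physicochemical assay for solubility, using the shake flask method, in phosphate buffer, measured as kinetic solubility, with a stated time of 20 h, at pH 6.5 (a higher number here means a more soluble compound, a lower number a less soluble compound), compound 1 `FC(F)(F)c1ccc(Nc2cc3[nH]c(-c4cccc(C(F)(F)F)c4)nc3cn2)nc1` gives < 5000 nM, which is a limit of the assay. Compound 2 `NC(=O)c1ccc(Nc2cc3[nH]c(-c4cccc(C(F)(F)F)c4)nc3cn2)nc1` gives < 5000 nM, which is also a limit and not a number. For the measured compounds named here, both values sit at one shared limit, (the limit of < 5000 nM in this assay, at which 2 of the 2 values shown sit), so the only measured step, a step that the two limits leave unreadable from compound 1 to compound 2, has no readable size. Compound 3 `CN1CCN(c2ccc(Nc3cc4[nH]c(-c5cccc(C(F)(F)F)c5)nc4cn3)nc2)CC1` differs from compound 2 by 4-methylpiperazin-1-yl in place of carbamoyl on an aromatic carbon, with 4-methylpiperazin-1-yl in place of carbamoyl on an aromatic carbon. No measured step sizes this change, so the estimate is loose. The expected step is upward, an at least 2.0-fold higher number from compound 2 to compound 3 (0.30 log units; that floor lies within the scatter). Compound 3 is estimated at 10000 nM, within an expected range of 3000 nM to 60000 nM.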

Compound 3, solubility: 66000 nM
Estimate against measurement, compound 3: 6.6-fold (0.82 log units) below; the whole stated range lies below it.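

In this assay, this place on the aromatic carbon two atoms from the ring nitrogen now gives a readable step, with 4-methylpiperazin-1-yl in place of carbamoyl: an at least 13-fold higher number from compound 2 to compound 3 (1.12 log units; beyond the scatter). The same group in place of trifluoromethyl gives an at least 13-fold higher number from compound 1 to compound 3 (1.12 log units; beyond the scatter). Compound 1 and compound 2 alone could not show that a change here lifts the read-out off their shared limit: the limit of < 5000 nM in this assay, at which 2 of the 3 values shown sit.

The step between compound 1 and compound 2 still cannot be read. Also open, going by these compounds, is whether a morpholine or a dimethylamino group at this place would give a step of similar size.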